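Hydrazone and Diacylhydrazine Analogues Compared for Cytotoxicity

A few compounds are considered here, and "the series" means these few. Any claim that something is new, unique, unknown or untested is made for them only; others in the source may bear on it.

Four compounds built around a di-iodinated hydroxyphenyl unit are compared here. Compound 1 `O=C(N/N=C/c1cc(I)cc(I)c1O)c1ccc(C(F)(F)F)cc1` and compound 2 `O=C(N/N=C/c1cc(I)cc(I)c1O)c1ccc([N+](=O)[O-])cc1` share a hydrazone core, while compound 3 `O=C(NNC(=O)c1cc(I)cc(I)c1O)c1ccc(C(F)(F)F)cc1` and compound 4 `O=C(NNC(=O)c1cc(I)cc(I)c1O)c1ccc([N+](=O)[O-])cc1` carry a diacylhydrazine core; the difference between the two cores is not broken down here.

In a functional assay on HepG2 cells (Homo sapiens) for cytotoxicity, with a stated time of 24 h (a lower number here means a stronger inhibitor, a higher number a weaker inhibitor), compound 1 gives 11700 nM. Compound 2 differs from it by nitro in place of trifluoromethyl on an aromatic carbon, and this change produced a 2.1-fold higher number from compound 1 to compound 2 (0.32 log units; beyond the scatter), so that in this assay compound 2 gives 24700 nM. Compound 3, on the other core, gives in this assay 167000 nM, the highest number of the three that were measured.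

Compound 4 differs from compound 3 by nitro in place of trifluoromethyl on an aromatic carbon. For the measured compounds named here, this is the same change as the one from compound 1 to compound 2, on an equally placed aromatic carbon, and it is seen only that one time among the measured compounds. Resting on that single step of compound 1 to compound 2 a 2.1-fold higher number from compound 1 to compound 2 (0.32 log units; beyond the scatter), the expected step for compound 4 is a modest rise, a 1.8-fold higher number from compound 3 to compound 4 (0.25 log units; within the scatter), since nothing in the data suggests the core alters the direction of this change. The estimate for compound 4 in this assay is therefore 300000 nM, with a range from 120000 nM to 700000 nM.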

Compound 4, half-maximal inhibitory concentration: 159000 nM
Beside the measured number, compound 4's estimate is 1.9-fold (0.28 log units) above it, and the stated range covers the measured number.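

In this assay, nitro in place of trifluoromethyl gives a 1.1-fold lower number from compound 3 to compound 4 (0.02 log units; within the scatter), so on the core of compound 3 this change leaves no difference that can be read, whereas on the core of compound 1 it gave a 2.1-fold higher number from compound 1 to compound 2 (0.32 log units; beyond the scatter). Set side by side, the two steps cannot be told apart, even though only the first lies beyond the scatter: the same change on two cores in this assay, a 2.1-fold higher number (0.32 log units; beyond the scatter) from compound 1 to compound 2 and a 1.1-fold lower number (0.02 log units; within the scatter) from compound 3 to compound 4, 2.2-fold (0.35 log units) apart, within the scatter of two such steps The series is therefore consistent with this change carrying over from one core to the other, but with a single pair on each core and a single cell assay, it does not show that the step has the same size or direction on both, and it says nothing about any further core.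

The compounds shown leave open whether a nitrile, an amine or a carboxylic acid on the same aromatic carbon would also give similar steps on the two cores. They also leave open how the numbers would respond if chlorine or bromine took the place of the iodine atoms on the hydroxyphenyl unit, or if a methoxy group took the place of its hydroxyl.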